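The source may hold more compounds than are shown below. What is called first, only, known or untested is meant among the compounds shown, and "the series" means these compounds.

Compound 1 `Oc1ccc(-c2cc(-c3ccccc3F)cc(-c3cccc(O)c3)n2)cc1` gives 5630 nM in a functional assay on HCT-15 cells (Homo sapiens) for inhibition (a lower number here means a stronger inhibitor, a higher number a weaker inhibitor), and compound 2 `Oc1ccc(-c2cc(-c3ccccc3F)cc(-c3ccc(O)cc3)n2)cc1` gives 8180 nM in this assay. The change between them, (4-hydroxyphenyl in place of 3-hydroxyphenyl on an aromatic carbon), produced a 1.5-fold higher number from compound 1 to compound 2 (0.16 log units; within the scatter). Compound 3 `Oc1cccc(-c2cc(-c3ccccc3C(F)(F)F)cc(-c3cccc(O)c3)n2)c1` gives 8150 nM in this assay; how its core differs from that of compound 1 is not broken down here. Compound 4 `Oc1ccc(-c2cc(-c3ccccc3C(F)(F)F)cc(-c3cccc(O)c3)n2)cc1` is reached from compound 3 by the same kind of change, (4-hydroxyphenyl in place of 3-hydroxyphenyl on an aromatic carbon), though the place now sits meta to a 2-(trifluoromethyl)phenyl group and meta to a 3-hydroxyphenyl group rather than meta to a 2-fluorophenyl group and meta to a 4-hydroxyphenyl group. Compound 4 is expected to show a 1.3-fold higher number from compound 3 to compound 4 (0.11 log units; within the scatter) in this assay, because the earlier step gave a 1.5-fold higher number from compound 1 to compound 2 (0.16 log units; within the scatter). Compound 4 is therefore estimated at 10500 nM in this assay, between 5000 nM and 22000 nM.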

Compound 4, half-maximal inhibitory concentration: 5740 nM
Estimate against measurement, compound 4: 1.8-fold (0.26 log units) above; the range from low to high includes it.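

In this assay, putting 4-hydroxyphenyl in place of 3-hydroxyphenyl gave a 1.4-fold lower number from compound 3 to compound 4 (0.15 log units; within the scatter), and the two readings of this change do not differ beyond what repeated measurement allows: the same change on two cores in this assay, a 1.5-fold higher number (0.16 log units; within the scatter) from compound 1 to compound 2 and a 1.4-fold lower number (0.15 log units; within the scatter) from compound 3 to compound 4, 2.1-fold (0.31 log units) apart, within the scatter of two such steps. Both steps lie within the scatter, as does trifluoromethyl in place of fluoro, which gave a 1.0-fold higher number from compound 1 to compound 4 (0.01 log units; within the scatter), so on these two cores the change carries over as no measurable effect. This does not show that the change would stay without effect on other cores, since two pairs that both lie within the scatter reveal no real effect to transfer. The compounds shown leave open whether any change in this series separates clearly from the scatter. As far as these compounds go, what an amine or a methoxy group in place of the hydroxyl would give also remains open.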